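The source may report more compounds than this note shows. Statements on the series, on what has been measured and on what is new or still open speak of the compounds shown alone.

Of the compounds shown here, three have so far been measured in an assay on microsomes from liver for inhibition of 3-hydroxy-3-methylglutaryl-coenzyme A reductase (Rattus norvegicus); a lower number here means a stronger inhibitor, a higher number a weaker inhibitor. Compound 1 `CC(C)c1c(C(=O)N(C)Cc2ccccc2)nn(-c2ccc(F)cc2)c1CC[C@@H](O)C[C@@H](O)CC(=O)O` gives 6.2 nM, compound 2 `Cc1ccc(CNC(=O)c2nn(-c3ccc(F)cc3)c(CC[C@@H](O)C[C@@H](O)CC(=O)O)c2C(C)C)cc1` gives 2.5 nM, and compound 3 `CC(C)c1c(C(=O)NCc2cccc(F)c2F)nn(-c2ccc(F)cc2)c1OC[C@@H](O)C[C@@H](O)CC(=O)O` gives 2 nM. Compound 3 thus stands at the low end of the three numbers; its gap to compound 2 lies within the usual scatter, while its gap to compound 1 lies beyond it. Among the measured compounds shown here, the only step between measured compounds, a 2.5-fold lower number from compound 1 to compound 2 (0.39 log units; beyond the scatter), concerns the group carried by the amide nitrogen and was modest. Compound 4 `CC(C)c1c(C(=O)NCc2ccccn2)nn(-c2ccc(F)cc2)c1OC[C@@H](O)C[C@@H](O)CC(=O)O` differs from compound 3 by pyridin-2-yl in place of 2,3-difluorophenyl on a saturated chain carbon bound to an amide-type nitrogen. This change also falls on the group carried by the amide nitrogen, so the step from compound 1 to compound 2 is the only one that bears on it, and it was modest. For the measured compounds named here, no measured pair exchanges a carbon-only aromatic ring for a ring with one hetero atom, so the direction cannot be read from the data. For compound 4 a small step, probably not beyond the scatter, is expected, namely a 1.5-fold higher number from compound 3 to compound 4 (0.18 log units; within the scatter). Compound 4 is therefore estimated at 3 nM, within a range from 1.5 nM to 8 nM.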

Compound 4, half-maximal inhibitory concentration: 25 nM
Estimate against measurement, compound 4: 8.3-fold (0.92 log units) below, outside the stated range (above it).
By their numbers in this assay, from the lowest: compounds 3 and 2 (each within the scatter of the next); then compound 1; then compound 4.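

In this assay, among the compounds shown here, the step of a 13-fold higher number from compound 3 to compound 4 (1.10 log units; beyond the scatter) is large, whereas the only earlier step on the group carried by the amide nitrogen, a 2.5-fold lower number from compound 1 to compound 2 (0.39 log units; beyond the scatter), was modest. The aromatic ring on this saturated chain carbon bound to an amide-type nitrogen is therefore not freely exchangeable in this series, since pyridin-2-yl in place of 2,3-difluorophenyl moves the number well beyond the scatter. Nothing available explains this loss.

The single exchange removes the fluorine atoms and brings in a ring nitrogen together, so the compounds shown cannot say which of the two carries the step. An unsubstituted phenyl, a pyridin-3-yl or a pyridin-4-yl on the same carbon would separate these two parts.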